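Amino for Chloro on a Shared Core

A few compounds are considered here, and "the series" means these few. Any claim that something is new, unique, unknown or untested is made for them only; others in the source may bear on it.

Compound 1 `ClCc1cccc(Cn2cnc3c(Cl)nc(Cl)nc32)c1` carries two chloro groups on its core and was tested in a functional assay on HT-29 cells (Homo sapiens) for cytotoxicity, read by sulforhodamine B assay, with a stated time of 48 h; on this read-out higher numbers stand for weaker inhibition of growth and lower numbers for stronger inhibition of growth. In this assay compound 1 gives > 100000 nM, which is a limit of the assay rather than a number. Compound 2 `ClCc1ccccc1Cn1cnc2nc(Cl)nc(Cl)c21` was tested in this assay as well and gives > 100000 nM, again a limit and not a number. Going by the values given here, compound 1 thus stands at the limit of > 100000 nM in this assay, at which 2 of the 2 values shown sit, with no measured compound showing a numerical value. Compound 3 `Nc1nc(Cl)c2ncn(Cc3cccc(CCl)c3)c2n1` has not yet been measured. It differs from compound 1 by amino in place of chloro on an aromatic carbon. Among the compounds with values here, no step between measured compounds is available, so the step from compound 1 to compound 3 can only be expected; the estimate is a number no higher from compound 1 to compound 3 (the limit leaves the size open), which is none beyond the scatter. Compound 3 is therefore expected to give about 100000 nM in this assay, with a range from 30000 nM to 300000 nM, and a limit is the likeliest outcome.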

Compound 3, concentration for total growth inhibition: 9770 nM
The estimate for compound 3 lay 10-fold (1.01 log units) above the measured number; measured number below the stated range.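

In this assay, amino in place of chloro on this aromatic carbon, between two ring nitrogen atoms, gives an at least 10-fold lower number from compound 1 to compound 3 (1.01 log units; beyond the scatter). This shows that a change of a single heavy atom at this position of the shared core can bring growth inhibition into a measurable range. The starting point of this step is a limit and not a number, so the full size of the step stays unknown, and compound 3 is the only compound shown with a numerical value, the others sitting at a limit: the limit of > 100000 nM in this assay, at which 2 of the 3 values shown sit.

The compounds shown leave open whether the gain comes from adding amino or from losing chloro, which a hydrogen, a hydroxyl or a methylamino group at this position could help to separate. They also leave open whether the same change would lower the number for compound 2.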